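Phenethyl for 3-fluorophenyl on a sulfur in compound 1

The source may hold more compounds than are shown below. What is called first, only, known or untested is meant among the compounds shown, and "the series" means these compounds.

In a functional assay on SMMC-7721 cells (Homo sapiens) for inhibition, read by CCK-8 assay, with a stated time of 72 h, tested at 2 uM (on this read-out lower numbers stand for less inhibition of growth and higher numbers for more inhibition of growth at the one concentration tested), compound 1 (`Nc1ccccc1NC(=O)/C=C/c1ccc(CSc2cccc(F)c2)cc1`) gives 8.56%. Compound 3 (`Nc1ccccc1NC(=O)c1ccc(CSc2ccc(Br)cc2)cc1`) gives 10%, within the scatter of compound 1. Compound 2 (`Cc1ccc(SCc2ccc(C(=O)Nc3ccccc3N)cc2)cc1`) gives 25.1%, beyond the scatter above compound 1. Compound 1 therefore stands level with compound 3 at the low end of the three numbers.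

Compound 4 (`Nc1ccccc1NC(=O)/C=C/c1ccc(CSCCc2ccccc2)cc1`) has not yet been measured. Its difference from compound 1 is phenethyl in place of 3-fluorophenyl on a sulfur.

Going by the values given here, the only measured step is a number 15.1 percentage points lower from compound 2 to compound 3 (beyond the scatter), with bromo in place of methyl on an aromatic carbon. It is a different change at a different place, so it bears only loosely, as a guide to size. Among the compounds with values here, no measured step covers the change on the sulfur. A small upward move, not beyond the scatter, is expected in this assay. The estimated step is a number 4.4 percentage points higher from compound 1 to compound 4 (within the scatter). For compound 4 the estimated value is 13%, with an expected range from 1% to 30%.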

Compound 4, percent growth inhibition at one concentration: 14.7%
Estimate against measurement, compound 4: 1.7 percentage points below; measured number inside the range.
By their numbers in this assay, from the lowest: compounds 1, 3 and 4 (each within the scatter of the next); then compound 2.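

In this assay, the first step read at this position is a number 6.1 percentage points higher from compound 1 to compound 4 (within the scatter), with phenethyl in place of 3-fluorophenyl on a sulfur. The change from (3-fluorophenyl)sulfanyl to phenethylsulfanyl removes the fluorine and adds a carbon chain before the aromatic ring, yet it does not move the number beyond the scatter, so this one swap shows no separation between the two groups at the concentration tested. Nothing measured here bears on what lies behind the size of this step.

Open, as far as these compounds go, is whether a group of another kind on the sulfur, such as a chain ending in an amine or a carboxylic acid, would give a step beyond the scatter. Also open, from the compounds shown here alone, is whether phenethyl in place of 3-fluorophenyl would give a step of similar size on the core of compound 2.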